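The source may hold more compounds than are shown below. What is called first, only, known or untested is meant among the compounds shown, and "the series" means these compounds.

Compound 1 `COc1ccc(/C=C/c2cc(=O)cco2)cc1` and compound 2 `COc1ccc(/C=C/c2cc(=O)cco2)cc1OC` share one core, while compound 3 `COc1ccc(/C=C/C2CC=CC(=O)N2)cc1OC` and compound 4 `COc1cc(OC)c(OC)cc1/C=C/C1CC=CC(=O)N1` share another; how the two cores differ is not broken down here. In a functional assay on MCF7 cells (Homo sapiens) for inhibition, read by sulforhodamine B assay, with a stated time of 48 h (a higher number here means a weaker inhibitor of growth, a lower number a stronger inhibitor of growth), compound 1 gives 396 uM. In this assay compound 2 gives 954 uM. The change between them is methoxy in place of hydrogen on an aromatic carbon, and it brings a 2.4-fold higher number from compound 1 to compound 2 (0.38 log units; beyond the scatter).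

For compound 3 this assay reports only a limit, > 964 uM, and no number.

Compound 4 arises from compound 3 by methoxy in place of hydrogen on an aromatic carbon. Going by the values given here, this is the same kind of change as the one from compound 1 to compound 2, but the surroundings are not the same: in compound 2 the entering methoxy sits ortho to a methoxy group and meta to a group of 9 heavy atoms, whereas in compound 4 it sits ortho to a group of 9 heavy atoms, meta to a methoxy group and para to a methoxy group.

Among the compounds with values here, the expected step from compound 3 to compound 4 is a step that the limit leaves unreadable from compound 3 to compound 4, set beside the earlier step, because compound 3 already sits at the limit of > 964 uM in this assay, at which 1 of the 3 values shown sits, and the only measured instance of this kind of change raised the number. Compound 4 is therefore expected to give about 1800 uM in this assay, with a range of 700 uM to 5000 uM, and it is very likely that only a limit will again be reported.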

Compound 4, concentration for growth inhibition (reported as GI): > 864 uM
Compound 4: no number, only a limit; the forecaster's own chance of this, stated with the estimate: 85%; the middle value is on the limit's open side.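

No step can be read from compound 3 to compound 4 in this assay, as both compounds give only limits and no numbers. The compounds shown leave open what methoxy in place of hydrogen on an aromatic carbon does to the number on the core shared by compound 3 and compound 4, and whether a 2.4-fold higher number from compound 1 to compound 2 (0.38 log units; beyond the scatter) has any counterpart there.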